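The source may report more compounds than this note shows. Statements on the series, on what has been measured and on what is new or still open speak of the compounds shown alone.

Measured so far in a functional assay on MGC-803 cells (Homo sapiens) for inhibition, read by MTT assay, with a stated time of 72 h; on this read-out higher numbers stand for weaker inhibition and lower numbers for stronger inhibition:
compound 1 `Cc1ccc(Cn2cc(CSC(=S)N3CCN(C(=O)OCc4ccccc4)CC3)nn2)cc1` — 9370 nM
compound 2 `COc1cc(Cn2cc(CSC(=S)N3CCN(C(=O)OCc4ccccc4)CC3)nn2)cc(OC)c1OC` — 10900 nM

For the measured compounds named here, only two numbers exist, and they sit close together: a 1.2-fold higher number from compound 1 to compound 2 (0.07 log units; within the scatter). Compound 2 therefore cannot be set apart from compound 1 on this read-out; the two values are indistinguishable within the usual scatter.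

Compound 3 `COc1cc(Cn2cc(CSC(=S)N3CCN(C(=O)OC(C)(C)C)CC3)nn2)cc(OC)c1OC` is the next member. It differs from compound 2 by tert-butyl in place of benzyl on an oxygen next to a carbonyl group. Going by the values given here, the single measured step concerns a different site, the aryl group on the benzylic carbon attached to the triazole nitrogen, so no measured step bears directly on an exchange at the carbamate oxygen. With nothing in the series speaking for a change at this position, the working expectation is no step beyond the scatter, a 1.0-fold higher number from compound 2 to compound 3 (0.00 log units; within the scatter). Compound 3 is accordingly estimated at 11000 nM in this assay, with a range of 4000 nM to 30000 nM, the width reflecting the absence of any directly comparable step.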

Compound 3, half-maximal inhibitory concentration: 27300 nM
Estimate against measurement, compound 3: 2.5-fold (0.39 log units) below; low and high end bracket the measured number.
By their numbers in this assay, from the lowest: compounds 1 and 2 (each within the scatter of the next); then compound 3.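

This position responds to change: in this assay, tert-butyl in place of benzyl on an oxygen next to a carbonyl group gives a 2.5-fold higher number from compound 2 to compound 3 (0.40 log units; beyond the scatter), a modest step beyond the scatter. For the compounds shown here, the only earlier step, at the aryl group, stayed within the scatter at a 1.2-fold higher number from compound 1 to compound 2 (0.07 log units; within the scatter), so this is the first exchange to move the number. Of this pair, benzyl goes with the stronger inhibition, but that reading rests on this single pair, and nothing available here explains the step.

From the compounds shown here alone, whether the aromatic ring or some other feature of benzyl carries the difference stays open, as does the outcome with a longer chain such as phenylethyl, or with a plain methyl, on that oxygen. Also open, going by these compounds, is whether the exchange gives a similar step alongside 4-methylphenyl rather than 3,4,5-trimethoxyphenyl.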